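The source may report more compounds than this note shows. Statements on the series, on what has been measured and on what is new or still open speak of the compounds shown alone.

In a functional assay on HCT-116 cells (Homo sapiens) for antiproliferative activity, read by MTT assay, with a stated time of 48 h (a higher number here means a weaker inhibitor, a lower number a stronger inhibitor), the series reads as follows:

compound 1 `COc1ccc(CN(C(=O)CSc2nc3ccccc3s2)c2cc(OC)c(OC)c(OC)c2)cc1` gives 426 nM
compound 2 `COc1ccc2nc(SCC(=O)N(Cc3ccc(OC)c(O)c3)c3cc(OC)c(OC)c(OC)c3)sc2c1` gives 352 nM
compound 3 `COc1ccc(CN(C(=O)CSc2nc3cc(Cl)ccc3s2)c2cc(OC)c(OC)c(OC)c2)cc1O` gives 429 nM

Compound 1 lies within the scatter of both compound 2 and compound 3, so the three values form one flat group. Compound 4 `COc1cc(N(Cc2ccccc2)C(=O)CSc2nc3ccccc3s2)cc(OC)c1OC` has hydrogen in place of methoxy on an aromatic carbon, para to a large group, turning 4-methoxybenzyl into benzyl (hydrogen in place of methoxy on an aromatic carbon). Going by the values given here, the only measured single-place step (a 1.2-fold higher number from compound 2 to compound 3 (0.09 log units; within the scatter)) changes a different group and gives no size for this one. Among the compounds with values here, all three measured compounds keep this methoxy, so no direct precedent exists. A modest move toward a higher number is expected on the structural change alone, with the estimated step being a 1.9-fold higher number from compound 1 to compound 4 (0.27 log units; within the scatter) and wide uncertainty. Compound 4 is estimated at 800 nM (expected range 280 nM to 2500 nM).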

Compound 4, half-maximal inhibitory concentration: 54500 nM
Compound 4: the middle estimate sits 68-fold (1.83 log units) below what was measured; the whole stated range lies below it.
By their numbers in this assay, from the lowest: compounds 2, 1 and 3 (each within the scatter of the next); then compound 4.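

In this assay, hydrogen in place of methoxy gives a 130-fold higher number from compound 1 to compound 4 (2.11 log units; beyond the scatter) and so turns 4-methoxybenzyl into benzyl. This places a steep dependence on this single position, on an aromatic carbon para to a large group, which compounds 1, 2 and 3 could not reveal since all three keep the methoxy. Nothing shown accounts for the size of this step.

From the compounds shown here alone, whether an ethoxy group, a chlorine atom or an amine at this place would hold the level of compound 1 stays open. Also open, going by these compounds, is whether the same change would cost as much alongside the substituted cores of compound 2 and compound 3.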